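The source may hold more compounds than are shown below. What is called first, only, known or untested is meant among the compounds shown, and "the series" means these compounds.

Measured compounds:
Compound 1, `Cc1ccnc(/C(N)=N/NC(=S)N2CCOCC2)c1`, which in a functional assay on A-431 cells (Homo sapiens) for cytotoxicity, read by MTT assay, with a stated time of 72 h, tested at 100 uM (on this read-out lower numbers stand for less inhibition of growth and higher numbers for more inhibition of growth at the one concentration tested), gives 82.8%.
Compound 2, `N/C(=N\NC(=S)N1CCCC1)c1ccccn1`, which in this assay gives 83.8%.

Compound 2 and compound 1 give numbers that lie within the scatter of each other, so neither can be set apart from the other on these two measurements alone.

Compound 3, `Cc1ccnc(/C(N)=N/NC(=S)N2CCCC2)c1`, has not yet been measured. It differs from compound 2 by a single change: methyl in place of hydrogen on an aromatic carbon. Compound 1 already carries the same methyl on the same ring, and compound 1 and compound 2 give numbers within the scatter of each other, which suggests that this methyl does not move the read-out. Among the compounds with values here, no step between two measured compounds isolates this change, so the expectation rests on that comparison only.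

The estimated step of a number 0.8 percentage points lower from compound 2 to compound 3 (within the scatter) is expected to lie within the scatter, with no direction beyond it. Compound 3 is therefore expected to give about 83% in this assay, between 70% and 93%.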

Compound 3, percent growth inhibition at one concentration: 86.9%
Estimate against measurement, compound 3: 3.9 percentage points below; low and high end bracket the measured number.
By their numbers in this assay, from the lowest: compounds 1, 2 and 3 (each within the scatter of the next).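

Methyl in place of hydrogen on an aromatic carbon, opposite the ring nitrogen, gives a number 3.1 percentage points higher from compound 2 to compound 3 (within the scatter) in this assay and so supplies the direct comparison at this position that the earlier compounds lacked, showing that this change cannot be told from the scatter. With the methyl held constant, pyrrolidin-1-yl in place of morpholin-4-yl on a thiocarbonyl carbon gives a number 4.1 percentage points higher from compound 1 to compound 3 (within the scatter) and likewise cannot be told from the scatter, so neither change sets these compounds apart at the one concentration tested. No measurement at hand bears on why either step has this size.

The compounds shown carry only hydrogen or methyl at this position, so it remains open whether a methoxy group, an amine or a longer chain there would give a step beyond the scatter. From the compounds shown here alone, it also remains open whether the compounds would separate at lower concentrations.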